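Trimming the imine arm of compound 1 to a hydroxy

A few compounds are considered here, and "the series" means these few. Any claim that something is new, unique, unknown or untested is made for them only; others in the source may bear on it.

Measured compounds:
- compound 1, `O=c1cc(/C=N\c2ccccc2O)c2ccc(OCc3ccccc3)cc2o1`: 1290 nM
- compound 2, `O=c1cc(/C=N\c2ccccc2O)c2c(OCc3ccccc3)cc(OCc3ccccc3)cc2o1`: 7760 nM
- compound 3, `O=c1cc(/C=N\Nc2ccc([N+](=O)[O-])cc2)c2c(OCc3ccccc3)cc(OCc3ccccc3)cc2o1`: 15500 nM

All three were tested in a functional assay, read by spectrophotometry, with a stated time of 3 min; on this read-out higher numbers stand for weaker inhibition and lower numbers for stronger inhibition. Compound 1 gives the lowest number of the three; compound 2 sits nearest to it, and the step of a 6.0-fold higher number from compound 1 to compound 2 (0.78 log units; beyond the scatter) comes from adding a benzyloxy group on the shared core. The step of a 2.0-fold higher number from compound 2 to compound 3 (0.30 log units; within the scatter) changes the group hanging on the double-bonded nitrogen and stays within the scatter.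

Compound 4, `O=c1cc(/C=N\O)c2ccc(OCc3ccccc3)cc2o1`, has not yet been measured in this assay. It differs from compound 1 in one place: hydroxy in place of 2-hydroxyphenyl on a double-bonded nitrogen. Among the measured compounds shown here, no measured step swaps this group for so small a one; the only change made on the same nitrogen is the step from compound 2 to compound 3, which was within the scatter. On that slender basis, compound 4 is expected to give a number close to compound 1 or somewhat higher, a 1.9-fold higher number from compound 1 to compound 4 (0.29 log units; within the scatter). The estimate for compound 4 is 2500 nM, with a range from 800 nM to 8000 nM.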

Compound 4, half-maximal inhibitory concentration: 22800 nM
The estimate for compound 4 lay 9.1-fold (0.96 log units) below the measured number; measured number outside the range, above it.
By their numbers in this assay, from the lowest: compound 1; then compounds 2, 3 and 4 (each within the scatter of the next, the first and the last beyond it).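

On the double-bonded nitrogen, hydroxy in place of 2-hydroxyphenyl gives an 18-fold higher number from compound 1 to compound 4 (1.25 log units; beyond the scatter) in this assay and so a large loss of inhibition, which shows that this position is not indifferent to the group it carries. Among the compounds shown here, the only earlier change on this nitrogen, on a different core, was a 2.0-fold higher number from compound 2 to compound 3 (0.30 log units; within the scatter) and swapped one ring-bearing group for another, whereas this change removes the six-membered aromatic ring and leaves the counts of hydrogen-bond donors and acceptors the same. No measurement here explains the loss.

The compounds shown cannot separate the loss of the ring from the loss of heavy atoms. On the core of compound 1, a plain phenyl would test the ring without its hydroxy, and a methoxy or a longer chain such as butoxy would test size without a ring.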